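This account rests on a few compounds, and the source may have more. Where it says the series, first, only, none or still open, it means among the compounds named here.

Measured compounds and their values in a physicochemical assay for solubility, read by LC-MS, in phosphate buffer, with a stated time of 24 h, at pH 7.4; a higher number here means a more soluble compound, a lower number a less soluble compound:

Compound 1, `CN(c1ccn(C)n1)c1cnc(NCc2c(F)ccc3c2CCO3)c2cn[nH]c(=O)c12`: 12000 nM
Compound 2, `O=C1CC2(CC2)CN1c1cnc(NCc2c(F)ccc3c2CCO3)n2cnnc12`: 130000 nM
Compound 3, `CN(c1ncco1)c1cnc(NCc2c(F)ccc3c2CCO3)n2cnnc12`: 67000 nM

Among these three, compound 3 gives the second highest number in this assay. Its nearest neighbour is compound 2, and the difference between them, a 1.9-fold lower number from compound 2 to compound 3 (0.29 log units; within the scatter), lies within the scatter, so the two cannot be ordered. Among the compounds with values here, compound 1 stands furthest away, with a number well beyond the scatter below that of compound 3, but compound 1 also has a different core, so no single step connects it to compound 3.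

Compound 4, `CN(C(=O)c1ccccc1)c1cnc(NCc2c(F)ccc3c2CCO3)n2cnnc12`, has not yet been measured. It differs from compound 3 in one place: benzoyl in place of 1,3-oxazol-2-yl on a nitrogen on an aromatic ring. Within the data shown here, no measured step touches this nitrogen; the one counted step, a 1.9-fold lower number from compound 2 to compound 3 (0.29 log units; within the scatter), concerns a group on an aromatic carbon and is itself within the scatter. Among the measured compounds shown here, the data therefore offer no direct precedent for the change from 1,3-oxazol-2-yl to benzoyl.

For the measured compounds named here, with no guiding step, compound 4 is expected to stay close to compound 3, and the step of a 2.2-fold lower number from compound 3 to compound 4 (0.35 log units; beyond the scatter) is estimated to be small, with a lean toward a lower number. Compound 4 is accordingly estimated at 30000 nM in this assay, with a range from 8000 nM to 110000 nM.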

Compound 4, solubility: 280000 nM
The estimate for compound 4 lay 9.3-fold (0.97 log units) below the measured number, and the stated range ends below it.
By their numbers in this assay, from the lowest: compound 1; then compounds 3 and 2 (each within the scatter of the next); then compound 4.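

Within the data shown here, the group on this nitrogen on an aromatic ring turns out to matter in this assay: with benzoyl in place of 1,3-oxazol-2-yl, the result is a 4.2-fold higher number from compound 3 to compound 4 (0.62 log units; beyond the scatter), the first step at this nitrogen that can be read beyond the scatter. The earlier compounds shown here could not show this, as compounds 2 and 3 could not be ordered, whereas the group carried by compound 4 also separates from the lactam-containing group of compound 2, with a 2.2-fold higher number from compound 2 to compound 4 (0.33 log units; beyond the scatter), so compound 4 stands clear of both compounds on the shared core. The data at hand offer nothing that would explain either step.

The step from 1,3-oxazol-2-yl to benzoyl changes the ring and adds a carbonyl in one move, so the compounds shown do not tell which of the two goes with the higher number; an acetyl group or a plain phenyl on this nitrogen would separate them. They also leave open whether the step holds with a methoxy group or an amine on the benzoyl ring, or with ethyl in place of the methyl on the same nitrogen.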